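The source may hold more compounds than are shown below. What is called first, only, known or untested is meant among the compounds shown, and "the series" means these compounds.

Of the compounds shown here, three sharing one core have been measured in a functional assay on cells (Platelet, Homo sapiens) for inhibition; a lower number here means a stronger inhibitor, a higher number a weaker inhibitor. Compound 1 `CCOC(=O)c1ccc(-c2nn(CC)c3ccccc23)cc1` gives 360 nM. Compound 2 `CCCCn1nc(-c2ccc(C(=O)OCC)cc2)c2ccccc21` gives 670 nM; the change ethyl in place of hydrogen on a saturated chain carbon, two bonds along the chain from an aromatic nitrogen made a 1.9-fold higher number from compound 1 to compound 2 (0.27 log units; within the scatter). Compound 3 `COC(=O)c1ccc(-c2nn(Cc3ccccc3)c3ccccc23)cc1` gives 560 nM; how its core differs from the core of compound 1 is not broken down here. Compound 4 `CCCOC(=O)c1ccc(-c2nn(Cc3ccccc3)c3ccccc23)cc1` has not been measured; it carries ethyl in place of hydrogen on a saturated chain carbon bound to an oxygen next to a carbonyl group. This is the same kind of change as that between compound 1 and compound 2, not the same: there the place was a saturated chain carbon two bonds along the chain from an aromatic nitrogen, here it is a saturated chain carbon bound to an oxygen next to a carbonyl group. In this assay a step of a 1.4-fold higher number from compound 3 to compound 4 (0.15 log units; within the scatter) is expected, beside a 1.9-fold higher number from compound 1 to compound 2 (0.27 log units; within the scatter), resting only on that single earlier step at a different place. Compound 4 is estimated at 800 nM, expected between 350 nM and 1800 nM.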

Compound 4, half-maximal inhibitory concentration: > 10000 nM
Compound 4: a limit, no number; the forecaster's own chance of this, stated with the estimate: 3%; at least 12-fold (1.09 log units) between middle value and limit.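

In this assay ethyl in place of hydrogen on a saturated chain carbon bound to an oxygen next to a carbonyl group gives an at least 17-fold higher number from compound 3 to compound 4 (1.25 log units; beyond the scatter). Compound 4 gives > 10000 nM, which is a limit of the assay and not a number. The size of this change did not carry over from one core to the other, but with one pair per core and a different place in each pair, the data do not separate the effect of the core from that of the place: the same change on two cores in this assay, a 1.9-fold higher number (0.27 log units; within the scatter) from compound 1 to compound 2 and an at least 17-fold higher number (1.25 log units; beyond the scatter) from compound 3 to compound 4, at least 9.5-fold (0.98 log units) apart, beyond the scatter of two such steps.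

Open, on these data alone, is whether propoxycarbonyl on the core of compound 1 or ethoxycarbonyl on the core of compound 3 would show where the loss sets in. Also open, as far as these compounds go, is whether a carboxylic acid or an amide in place of the ester retains inhibition.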